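Swapping Hydroxyphenyl for Pyridyl on the Shared Core

The source may report more compounds than this note shows. Statements on the series, on what has been measured and on what is new or still open speak of the compounds shown alone.

In a functional assay on HepG2 cells (Homo sapiens) for cytotoxicity, read by MTT assay, with a stated time of 48 h (on this read-out higher numbers stand for weaker inhibition and lower numbers for stronger inhibition), compound 1 `Cc1ncc([N+](=O)[O-])n1CCSc1nnc(-c2ccccc2O)o1` gives 19600 nM, the higher of the two numbers measured, yet within the scatter of compound 2. Compound 2 `COc1ccc(-c2nnc(SCCn3c([N+](=O)[O-])cnc3C)o2)c(O)c1` gives 11000 nM, and the step of a 1.8-fold lower number from compound 1 to compound 2 (0.25 log units; within the scatter) lies within the scatter. Compound 3 `Cc1ncc([N+](=O)[O-])n1CCSc1nnc(-c2ccncc2)o1` is unmeasured; it differs from compound 1 by pyridin-4-yl in place of 2-hydroxyphenyl on an aromatic carbon. For the measured compounds named here, the only measured step concerns a methoxy added elsewhere and does not bear on this replacement, so nothing beyond the scatter is expected here. Compound 3 is therefore estimated at 20000 nM, with a range from 7000 nM to 60000 nM. That expectation amounts to a step of a 1.0-fold higher number from compound 1 to compound 3 (0.01 log units; within the scatter), inside the scatter.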

Compound 3, half-maximal inhibitory concentration: 14800 nM
Estimate against measurement, compound 3: 1.4-fold (0.13 log units) above; the range from low to high includes it.
By their numbers in this assay, from the lowest: compounds 2, 3 and 1 (each within the scatter of the next).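

At this place on the shared core, pyridin-4-yl in place of 2-hydroxyphenyl gives a 1.3-fold lower number from compound 1 to compound 3 (0.12 log units; within the scatter) in this assay. This swap removes the hydrogen-bond donor and brings a nitrogen into the six-membered ring, yet the two compounds remain within the scatter of each other. No measurement here offers an explanation for this result. Going by these compounds, it remains open whether a plain phenyl ring, or a phenyl ring carrying an amine or a carboxylic acid, would move the number beyond the scatter at this place.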